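Replacing Dimethylamino with a Hydroxymethylpiperidine on the Side Chain

The compounds below may be only part of what the source reports. "The series", "measured", "known", "first", "only" and "open" are said of these compounds alone.

Compound 1 `COc1cc2c(Nc3ccc(C#N)cc3)ncnc2cc1OCCCN(C)C` was tested in a functional assay on HepG2 cells (Homo sapiens) for antiproliferative activity, read by MTT assay, with a stated time of 72 h; on this read-out lower numbers stand for stronger inhibition and higher numbers for weaker inhibition. In this assay compound 1 reached only a limit, > 100000 nM, and that reading is the limit of > 100000 nM in this assay, at which 1 of the 3 values shown sits. Compound 2 `CCN(CC)CCCOc1cc2ncnc(Nc3ccc(C#N)cc3)c2cc1OC` gave 59400 nM in this assay, while compound 3 `COc1cc2c(Nc3ccc(C#N)cc3)ncnc2cc1OCCCN1CCCC1` gave 20900 nM. The steps between them are an at least 1.6-fold lower number from compound 1 to compound 2 (0.22 log units; that floor lies within the scatter), an at least 4.7-fold lower number from compound 1 to compound 3 (0.67 log units; beyond the scatter) and a 2.8-fold lower number from compound 2 to compound 3 (0.45 log units; beyond the scatter). Compound 4 `COc1cc2c(Nc3ccc(C#N)cc3)ncnc2cc1OCCCN1CCC(CO)CC1` differs from compound 1 in one place: 4-(hydroxymethyl)piperidin-1-yl in place of dimethylamino on a saturated chain carbon, three bonds along the chain from an oxygen on an aromatic ring. The step to compound 3 shows that a ring amine at this place lowers the number beyond the scatter, so a lower number is expected for compound 4 as well, an at least 4.0-fold lower number from compound 1 to compound 4 (0.60 log units; beyond the scatter). Compound 4 is therefore estimated at 25000 nM, with a range from 8000 nM to 100000 nM.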

Compound 4, half-maximal inhibitory concentration: 61800 nM
For compound 4 the middle estimate is 2.5-fold (0.39 log units) below the measured one, and the stated range covers the measured number.
By their numbers in this assay, from the lowest: compound 3; then compounds 2 and 4 (each within the scatter of the next). At a limit, above all of these: compound 1.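

A ring amine at this place does not by itself bring the lower number seen with pyrrolidin-1-yl, since 4-(hydroxymethyl)piperidin-1-yl gives a 3.0-fold higher number from compound 3 to compound 4 (0.47 log units; beyond the scatter). Against the open-chain diethylamino there is a 1.0-fold higher number from compound 2 to compound 4 (0.02 log units; within the scatter), and against dimethylamino there is an at least 1.6-fold lower number from compound 1 to compound 4 (0.20 log units; that floor lies within the scatter). Compound 1 is a limit, so that last step is only a floor: the limit of > 100000 nM in this assay, at which 1 of the 4 values shown sits.

The compounds shown leave open how an unsubstituted piperidine, a morpholine or a longer chain would read here. They also leave open whether ring size or the hydroxymethyl group separates compound 4 from compound 3.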